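Extending the Alkoxy Group on the Aryl Ring of Compound 3

The source may report more compounds than this note shows. Statements on the series, on what has been measured and on what is new or still open speak of the compounds shown alone.

The three measured compounds and their numbers in a functional assay on PC-3 cells (Homo sapiens) for inhibition, read by sulforhodamine B assay, with a stated time of 48 h, tested at 50 uM (a higher number here means more inhibition of growth at the concentration tested, a lower number less inhibition of growth), are these:
compound 1, `COc1cc2c(cc1CC=C(C)C)C(=O)C[C@@H](c1ccc(Oc3ccccc3)cc1)O2`, gives 53%;
compound 2, `COc1cc2c(cc1CC=C(C)C)C(=O)C[C@@H](c1ccc(Oc3ccc(F)cc3)cc1)O2`, gives 19%;
compound 3, `COc1ccc([C@@H]2CC(=O)c3cc(CC=C(C)C)c(OC)cc3O2)cc1`, gives 58%.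

Compound 3 stands highest of the three numbers, though its gap to compound 1 is within the scatter; only compound 2 is set clearly apart, a number 39 percentage points higher from compound 2 to compound 3 (beyond the scatter). Across the measured steps, the exchange of the group on the oxygen mattered little in a number 5 percentage points higher from compound 1 to compound 3 (within the scatter), whereas the fluorine substitution on the outer ring made a large difference, a number 34 percentage points lower from compound 1 to compound 2 (beyond the scatter).

Compound 4, `CCCCOc1ccc([C@@H]2CC(=O)c3cc(CC=C(C)C)c(OC)cc3O2)cc1`, is reached from compound 3 by propyl in place of hydrogen on a saturated chain carbon bound to an oxygen on an aromatic ring. Among the compounds with values here, no measured step lengthens this chain, so the step from compound 1 to compound 3, in which a phenyl on that oxygen gave a number within the scatter of the methyl, is the nearest guide. On that basis a step within the scatter, or a modest drop at most, is expected, a number 8 percentage points lower from compound 3 to compound 4 (within the scatter). Compound 4 is therefore estimated to give 50% in this assay, with a range from 30% to 70%.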

Compound 4, percent growth inhibition at one concentration: 48%
For compound 4 the middle estimate is 2 percentage points above the measured one; the measured number falls inside the stated range.
By their numbers in this assay, from the lowest: compound 2; then compounds 4, 1 and 3 (each within the scatter of the next).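

In this assay, the change from methoxy to butoxy gives a number 10 percentage points lower from compound 3 to compound 4 (within the scatter) and so shows that a saturated chain on this oxygen can be longer than methyl without a step beyond the scatter. Butyl and phenyl on the same oxygen also cannot be told apart, with a number 5 percentage points lower from compound 1 to compound 4 (within the scatter) as their step, whereas butyl in place of 4-fluorophenyl gives a number 29 percentage points higher from compound 2 to compound 4 (beyond the scatter) and leaves compound 2 as the one compound set clearly apart. Methyl, butyl and phenyl on this oxygen thus all lie within the scatter of one another in compounds 3, 4 and 1, with compound 2 going against that pattern, and no measurement given here offers an explanation for either finding.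

The compounds shown leave open whether a longer chain than butyl, a branched chain such as isopropyl, or an amine at the end of the butyl would keep the number in this range. They also leave open whether chloro in place of the fluoro on the 4-fluorophenyl would bring the same large drop as fluoro does.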